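Sulfonamide aryl swap: from methoxyphenyl to dimethylphenyl

The compounds below may be only part of what the source reports. "The series", "measured", "known", "first", "only" and "open" are said of these compounds alone.

Three compounds have been measured in a functional assay on MCF7 cells (Homo sapiens) for antiproliferative activity, read by sulforhodamine B assay, with a stated time of 48 h; on this read-out higher numbers stand for weaker inhibition and lower numbers for stronger inhibition:
compound 1 `CCc1ccc(NS(=O)(=O)c2ccc(N3CCNC3=O)cc2)cc1` gives 810 nM;
compound 2 `O=C1NCCN1c1ccc(S(=O)(=O)Nc2ccc(F)c(F)c2)cc1` gives 620 nM;
compound 3 `COc1cccc(NS(=O)(=O)c2ccc(N3CCNC3=O)cc2)c1` gives 120 nM.

Compound 3 stands lowest of the three in this assay: the step of a 6.8-fold lower number from compound 1 to compound 3 (0.83 log units; beyond the scatter) and the step of a 5.2-fold lower number from compound 2 to compound 3 (0.71 log units; beyond the scatter) both lie beyond the scatter, whereas the step of a 1.3-fold lower number from compound 1 to compound 2 (0.12 log units; within the scatter) does not. Compound 4 `Cc1cccc(NS(=O)(=O)c2ccc(N3CCNC3=O)cc2)c1C` differs from compound 3 in one place: 2,3-dimethylphenyl in place of 3-methoxyphenyl on a sulfonamide nitrogen.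

Going by the values given here, no measured step covers this exact exchange. The two steps that bear on it, a 6.8-fold lower number from compound 1 to compound 3 (0.83 log units; beyond the scatter) and a 5.2-fold lower number from compound 2 to compound 3 (0.71 log units; beyond the scatter), show that the 3-methoxyphenyl group gave a lower number than either of the other two aryl groups tried. Replacing it with 2,3-dimethylphenyl gives up that group, so in this assay compound 4 is expected to move back toward the numbers of compound 1 and compound 2, by a step of a 2.7-fold higher number from compound 3 to compound 4 (0.43 log units; beyond the scatter). Compound 4 is therefore estimated at 320 nM, with a range from 110 nM to 950 nM.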

Compound 4, half-maximal inhibitory concentration: 230 nM
Compound 4: the middle estimate sits 1.4-fold (0.14 log units) above what was measured; the range from low to high includes it.
By their numbers in this assay, from the lowest: compounds 3 and 4 (each within the scatter of the next); then compounds 2 and 1 (each within the scatter of the next).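

In this assay, going by these compounds alone, the step of a 1.9-fold higher number from compound 3 to compound 4 (0.28 log units; within the scatter) shows that 3-methoxyphenyl is not the only group on the sulfonamide nitrogen to reach this range: 2,3-dimethylphenyl, which has no hydrogen-bond acceptor, cannot be told apart from it. The steps of a 2.7-fold lower number from compound 2 to compound 4 (0.43 log units; beyond the scatter) and a 3.5-fold lower number from compound 1 to compound 4 (0.55 log units; beyond the scatter) separate 2,3-dimethylphenyl from the other two aryl groups, so among these four compounds the oxygen of 3-methoxyphenyl is not required for the lower numbers. No measured evidence accounts for these differences.

On these data alone, it remains open whether 3-methylphenyl, with one of the two methyl groups gone, would stay with compound 3 and compound 4 in this assay. As far as these compounds go, the effect of an amine, a carboxylic acid or a longer chain such as ethoxy on the aryl ring is also open.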